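Carboxy for methoxy in compound 4: solubility outlook

The compounds below may be only part of what the source reports. "The series", "measured", "known", "first", "only" and "open" are said of these compounds alone.

Three members of the series have numbers in a physicochemical assay for solubility, using the shake flask method, measured as kinetic solubility, with a stated time of 20 h, at pH 2; on this read-out higher numbers stand for higher solubility and lower numbers for lower solubility. Compound 1 `COc1ccc(Nc2cc3[nH]c(-c4cccc(C(F)(F)F)c4)nc3cn2)nc1` gives only a limit in this assay, < 5000 nM. Compound 2 `Fc1ccc(-c2nc3cnc(Nc4ccccn4)cc3[nH]2)cc1F` gives 125000 nM in this assay. Compound 3 `Fc1ccc(-c2nc3cnc(Nc4ccc(C(F)(F)F)cn4)cc3[nH]2)cc1F` gives 6000 nM in this assay. Within the data shown here, the one measured step, a 21-fold lower number from compound 2 to compound 3 (1.32 log units; beyond the scatter), is the only single-site comparison in the set. Compound 1 stands at the limit of < 5000 nM in this assay, at which 1 of the 3 values shown sits, and cannot be placed against compound 2 or compound 3 by a number.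

Compound 4 `O=C(O)c1ccc(Nc2cc3[nH]c(-c4cccc(C(F)(F)F)c4)nc3cn2)nc1` is not yet measured. It differs from compound 1 in one place: carboxy in place of methoxy on an aromatic carbon. Cut one bond further out, the change reads 5-methoxypyridin-2-yl to 5-carboxypyridin-2-yl.

Among the measured compounds shown here, no measured step involves a methoxy or a carboxy, so the step from compound 2 to compound 3 does not bear on this change; it only shows how far a single-site change on this core can move this assay. With compound 1 sitting at a limit, the expected step of a number no lower from compound 1 to compound 4 (the limit leaves the size open) is taken as none beyond the scatter. Compound 4 is therefore expected at 5000 nM, within 1000 nM to 25000 nM, with a fair chance that this assay again returns only a limit.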

Compound 4, solubility: < 5000 nM
Compound 4: a limit, no number (the forecaster's own chance of this, stated with the estimate: 55%); the middle value sits exactly at the limit.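

In this assay compound 4 gives < 5000 nM as a limit and not a number. Among these compounds, compound 1 also gives a limit, so no step from compound 1 to compound 4 can be read. Left open is how the two compounds actually stand against each other, and whether carboxy in place of methoxy moves this read-out at all, with both values stopped at the same limit: the limit of < 5000 nM in this assay, at which 2 of the 4 values shown sit.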